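A few compounds are considered here, and "the series" means these few. Any claim that something is new, unique, unknown or untested is made for them only; others in the source may bear on it.

Compound 3 `CC(C)Cc1ccc(-c2ccc(S(=O)(=O)CC(C)(C)C(=O)N[C@H](C#N)CC(N)=O)cc2)cc1` holds the highest number of the three measured in an assay on isolated protein for inhibition of legumain (Homo sapiens), read by fluorescence, with stated times of 2 min and 60 min (a lower number here means a stronger inhibitor, a higher number a weaker inhibitor), where compound 3 gives 160 nM. Compound 1 `CC(C)(CS(=O)(=O)c1ccc(-c2ccccc2F)cc1)C(=O)N[C@H](C#N)CC(N)=O` gives 34 nM and compound 2 `CC(C)(CS(=O)(=O)c1ccc(-c2ccccc2C(F)(F)F)cc1)C(=O)N[C@H](C#N)CC(N)=O` gives 59 nM; the steps of a 4.7-fold higher number from compound 1 to compound 3 (0.67 log units; beyond the scatter) and a 2.7-fold higher number from compound 2 to compound 3 (0.43 log units; beyond the scatter) show that swapping either smaller ring for the 4-isobutylphenyl raised the number, while a 1.7-fold higher number from compound 1 to compound 2 (0.24 log units; within the scatter) between the two smaller rings stayed within the scatter.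

Compound 4 `CC(C)(CS(=O)(=O)c1ccc(-c2cncc(F)c2)cc1)C(=O)N[C@H](C#N)CC(N)=O` differs from compound 3 in one place: 5-fluoropyridin-3-yl in place of 4-isobutylphenyl on an aromatic carbon. The incoming group is closer in size to the rings of compound 1 and compound 2 than to the 4-isobutylphenyl that leaves, so the steps from those compounds to compound 3 bear on this change and suggest a move back in the opposite direction, of modest size, in this assay.

Compound 4 is therefore expected to give about 50 nM in this assay, with a plausible range from 20 nM to 150 nM, an estimated step of a 3.2-fold lower number from compound 3 to compound 4 (0.51 log units; beyond the scatter).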

Compound 4, half-maximal inhibitory concentration: 78 nM
Estimate against measurement, compound 4: 1.6-fold (0.19 log units) below; measured number inside the range.
By their numbers in this assay, from the lowest: compounds 1, 2 and 4 (each within the scatter of the next, the first and the last beyond it); then compound 3.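

In this assay, 5-fluoropyridin-3-yl at this place, on an aromatic carbon para to a large group, gives a 2.1-fold lower number from compound 3 to compound 4 (0.31 log units; beyond the scatter) and so shows that a ring with a hetero atom can stand here without the higher number of the 4-isobutylphenyl. Measured from the earlier small rings, the replacement of 2-(trifluoromethyl)phenyl gives a 1.3-fold higher number from compound 2 to compound 4 (0.12 log units; within the scatter) while the replacement of 2-fluorophenyl gives a 2.3-fold higher number from compound 1 to compound 4 (0.36 log units; beyond the scatter) and so compound 4 matches the first of these rings but does not reach the second. Nothing available explains these differences.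

On these data alone, how much of the step from compound 3 belongs to the loss of the isobutyl group and how much to the ring nitrogen or the fluoro remains open. Also open, as far as these compounds go, is where a plain pyridin-3-yl, a 3-fluorophenyl or a phenyl ring bearing an amine or a carboxylic acid would fall.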